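From compound 1 to compound 3: one methyl removed

A few compounds are considered here, and "the series" means these few. Any claim that something is new, unique, unknown or untested is made for them only; others in the source may bear on it.

Compound 1 `Cc1ccc(-c2ccsc2S(=O)(=O)NCCNC(=O)Nc2cc(C(F)(F)F)cc(C(F)(F)F)c2)c(Oc2ccc(O)c(O)c2)c1` gives 9700 nM as a number
Compound 2 `O=S(=O)(c1sccc1-c1ccccc1Oc1ccc(O)c(O)c1)N1CCN(C(=S)Nc2ccc(Cl)cc2)CC1` gives > 50000 nM as a limit

Among the measured compounds shown here, in a functional assay on HeLa cells (Homo sapiens) for inhibition, read by CCK-8 assay, with a stated time of 48 h (on this read-out higher numbers stand for weaker inhibition and lower numbers for stronger inhibition), compound 1 gives 9700 nM and this is the only true number available so far. Compound 2 gives only a limit in this assay, namely > 50000 nM and no number.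

Compound 3 `O=C(NCCNS(=O)(=O)c1sccc1-c1ccccc1Oc1ccc(O)c(O)c1)Nc1cc(C(F)(F)F)cc(C(F)(F)F)c1` has not yet been measured in this assay and stays close to compound 1. It carries a single change, hydrogen in place of methyl on an aromatic carbon or in words hydrogen in place of methyl on an aromatic carbon. For the measured compounds named here, no measured step shows what such a change does in this assay. With compound 1 at 9700 nM as the only anchor, no shift beyond the usual scatter is expected, in either direction. The expected change is a 1.1-fold higher number from compound 1 to compound 3 (0.05 log units; within the scatter) and it should stay within that scatter. For compound 3 the estimated value is 11000 nM with an expected range from 4500 nM to 28000 nM in this measurement.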

Compound 3, half-maximal inhibitory concentration: > 50000 nM
Compound 3: only a limit was reported; the forecaster's own chance of this, stated with the estimate: 10%; at least 4.5-fold (0.65 log units) between middle value and limit.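

Hydrogen in place of methyl on an aromatic carbon, meta to a 3,4-dihydroxyphenoxy group and para to a large group, gives an at least 5.1-fold higher number from compound 1 to compound 3 (0.71 log units; beyond the scatter) in this assay, the first single-place step in this set and one that shows this methyl position is not silent. In this assay compound 3 gives > 50000 nM, which is a limit of the assay and not a number. The step therefore sets only a lower bound on what losing the methyl costs, and its full size stays unknown because compound 3 ends at the same limit as most of the values shown: the limit of > 50000 nM in this assay, at which 2 of the 3 values shown sit.

The compounds shown leave open whether the methyl is specifically needed here or whether another group at this place, such as an ethyl, a methoxy group or a chlorine atom, would keep or strengthen the inhibition. They also leave open whether the methyl would count for as much if the linker of compound 1 were replaced by a longer chain.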